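Cyclohexyl in place of 4-ethoxyphenyl: working notes

The source may hold more compounds than are shown below. What is called first, only, known or untested is meant among the compounds shown, and "the series" means these compounds.

Measured in a functional assay on HeLa cells (Homo sapiens) for inhibition, read by sulforhodamine B assay; a higher number here means a weaker inhibitor, a lower number a stronger inhibitor:
- compound 1 (`CCc1ccc(NC2=CC(=O)c3c(nc4n3[C@H]3OC[C@@H](O)[C@H]3OC4)C2=O)cc1`): 6510 nM
- compound 2 (`O=C1C(N2CCCCC2)=CC(=O)c2c1nc1n2[C@H]2OC[C@@H](O)[C@H]2OC1`): > 16000 nM (a limit of the assay, not a number)
- compound 3 (`CCOc1ccc(NC2=CC(=O)c3c(nc4n3[C@H]3OC[C@@H](O)[C@H]3OC4)C2=O)cc1`): 14400 nM

Of the two actual numbers, compound 3 has the higher (14400 nM), and the nearest neighbour is compound 1 (6510 nM). Within the data shown here, the single step into compound 3 is modest: a 2.2-fold higher number from compound 1 to compound 3 (0.34 log units; beyond the scatter), with ethoxy in place of ethyl on an aromatic carbon.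

Compound 4 (`O=C1C(NC2CCCCC2)=CC(=O)c2c1nc1n2[C@H]2OC[C@@H](O)[C@H]2OC1`) has cyclohexyl in place of 4-ethoxyphenyl on an amine nitrogen. Among the measured compounds shown here, no measured step makes this exact exchange. The nearest is an at least 2.4-fold higher number from compound 1 to compound 2 (0.39 log units; beyond the scatter), with piperidin-1-yl in place of (4-ethylphenyl)amino. That step points towards a higher number, but it starts from compound 1, and compound 3 already stands above compound 1 by a 2.2-fold higher number from compound 1 to compound 3 (0.34 log units; beyond the scatter), so its size is not simply added here. Little change beyond the scatter is therefore expected in this assay, and a result reported only as a limit would be no surprise.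

The expected step is a 1.1-fold lower number from compound 3 to compound 4 (0.04 log units; within the scatter).

For compound 4 the estimated value is 13000 nM, with an expected range from 5500 nM to 30000 nM.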

Compound 4, half-maximal inhibitory concentration: > 16000 nM
Compound 4 ended at the assay's limit; the forecaster's own chance of this, stated with the estimate: 40%; middle value at least 1.2-fold (0.09 log units) from the limit.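

In this assay, compound 4 gives > 16000 nM, which is a limit of the assay and not a number. Exchanging the aromatic ring on the amine nitrogen for a non-aromatic six-membered ring gives an at least 2.4-fold higher number from compound 1 to compound 4 (0.39 log units; beyond the scatter), a step beyond the scatter, whereas an at least 1.1-fold higher number from compound 3 to compound 4 (0.04 log units; that floor lies within the scatter) has a floor within the scatter, so a difference from the 4-ethoxyphenyl compound is neither shown nor excluded. Among the four compounds, those without an aromatic ring on the double-bonded ring carbon's substituent, compound 2 and compound 4, both end at the same limit, so the step between them cannot be read and the two cannot be ranked: the limit of > 16000 nM in this assay, at which 2 of the 4 values shown sit.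

The compounds shown leave open how far past this limit compound 2 and compound 4 lie, and whether the aromatic ring itself is what separates them from compound 1 and compound 3. A plain phenyl, a benzyl or a cyclopentyl group on the same amine nitrogen would bear on that question, and a 4-carboxyphenyl group would extend the comparison among the aromatic members.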